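From 4-methoxyphenyl to 2,4-dihydroxyphenyl

The compounds below may be only part of what the source reports. "The series", "measured", "known", "first", "only" and "open" are said of these compounds alone.

Values measured in a functional assay on HT-29 cells (Homo sapiens) for inhibition, read by MTT assay, with a stated time of 48 h (a higher number here means a weaker inhibitor, a lower number a stronger inhibitor), for three compounds:
Compound 1 `COc1cc(-c2cc(-c3ccc(Br)cc3)nc(-c3ccccc3)n2)cc(OC)c1OC` gives 3170 nM here
Compound 2 `COc1cc(-c2cc(-c3ccc(C)cc3)nc(-c3ccccc3)n2)cc(OC)c1OC` gives > 25000 nM here, which is a limit and not a number
Compound 3 `COc1ccc(-c2cc(-c3cc(OC)c(OC)c(OC)c3)nc(-c3ccccc3)n2)cc1` gives 4230 nM here

Among the measured compounds shown here, compound 3 stands within the scatter of compound 1, and these are the only two exact numbers available. The next compound is compound 4 `COc1cc(-c2cc(-c3ccc(O)cc3O)nc(-c3ccccc3)n2)cc(OC)c1OC`, made by the change 2,4-dihydroxyphenyl in place of 4-methoxyphenyl on an aromatic carbon in which 2,4-dihydroxyphenyl replaces 4-methoxyphenyl. The measured steps show that a single swap on this aryl group can matter or not. The step of a 1.3-fold higher number from compound 1 to compound 3 (0.13 log units; within the scatter) is small, whereas an at least 5.9-fold lower number from compound 2 to compound 3 (0.77 log units; beyond the scatter) and an at least 7.8-fold higher number from compound 1 to compound 2 (0.89 log units; beyond the scatter) are clearly larger. None of these steps introduces a hydroxy group, so they give no firm direction for compound 4. The expected result in this assay is a 1.2-fold higher number from compound 3 to compound 4 (0.07 log units; within the scatter) and this estimate lies within the scatter, although the uncertainty is wide. For compound 4 the estimate is 5000 nM with an expected range from 1200 nM to 20000 nM.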

Compound 4, half-maximal inhibitory concentration: 4960 nM
Estimate against measurement, compound 4: 1.0-fold (0.00 log units) above, and the stated range covers the measured number.
By their numbers in this assay, from the lowest: compounds 1, 3 and 4 (each within the scatter of the next). At a limit, above all of these: compound 2.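

In this assay, among the compounds shown here, this is the first swap at this position to bring in hydroxy groups, and replacing 4-methoxyphenyl with 2,4-dihydroxyphenyl leaves the number within the scatter (a 1.2-fold higher number from compound 3 to compound 4 (0.07 log units; within the scatter)). The same is true when 2,4-dihydroxyphenyl replaces 4-bromophenyl (a 1.6-fold higher number from compound 1 to compound 4 (0.19 log units; within the scatter)), so compounds 1, 3 and 4 cannot be told apart here, while 4-methylphenyl remains the one group shown that stands clearly apart (an at least 5.0-fold lower number from compound 2 to compound 4 (0.70 log units; beyond the scatter)). That last step rests on a limit and not on a number, so its true size stays unknown: the limit of > 25000 nM in this assay, at which 1 of the 4 values shown sits.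

Still open, as far as these compounds go, is whether a single hydroxy group, as in 4-hydroxyphenyl, would give the same result as the two in compound 4. Also open, from the compounds shown here alone, is how an amine or a carboxylic acid on this aryl group would compare.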